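The source may hold more compounds than are shown below. What is called first, only, known or untested is meant among the compounds shown, and "the series" means these compounds.

In a functional assay on Bel7402/5-FU cells (Homo sapiens) for cytotoxicity, read by MTT assay, with a stated time of 72 h (on this read-out higher numbers stand for weaker inhibition and lower numbers for stronger inhibition), three compounds built on a shared core have been measured. Compound 1 `CC(=C\c1ccccc1)/C=C1\CCC=CC1=O` gives 4200 nM, compound 2 `O=C1C=CCC/C1=C\C=C\c1ccc(F)cc1` gives 1900 nM, and compound 3 `O=C1C=CCC/C1=C\C=C\c1ccc(Cl)cc1` gives 3200 nM, which lies within the usual scatter of both other compounds. Compound 4 `O=C1C=CCC/C1=C\C=C\c1ccc([N+](=O)[O-])cc1` has not yet been measured. It carries nitro in place of chloro on an aromatic carbon. Going by the values given here, only one measured step changes the same place, a 1.7-fold higher number from compound 2 to compound 3 (0.23 log units; within the scatter), and it stays within the scatter. That single step points in no firm direction, so no change beyond the scatter is expected in this assay. For compound 4 the estimated value is 2500 nM, with an expected range of 900 nM to 7000 nM. The expected step is a 1.3-fold lower number from compound 3 to compound 4 (0.11 log units; within the scatter).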

Compound 4, half-maximal inhibitory concentration: 4500 nM
Beside the measured number, compound 4's estimate is 1.8-fold (0.26 log units) below it; measured number inside the range.
By their numbers in this assay, from the lowest: compounds 2, 3, 1 and 4 (each within the scatter of the next, the first and the last beyond it).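

In this assay, going by these compounds alone, the change from chloro to nitro at this position gives a 1.4-fold higher number from compound 3 to compound 4 (0.15 log units; within the scatter) and does not separate the two groups, while the change from fluoro to nitro gives a 2.4-fold higher number from compound 2 to compound 4 (0.37 log units; beyond the scatter) and is the first step here to pass the scatter, though only modestly. Chloro stays within the scatter of both fluoro and nitro, so only the two ends of this small set can be told apart. No measurement here accounts for that gap. As far as these compounds go, whether an amine or a carboxylic acid at this position would give a larger step remains open.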